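The source may hold more compounds than are shown below. What is called first, only, known or untested is meant among the compounds shown, and "the series" means these compounds.

Measured so far:
Compound 1 `C(=C/c1nn2c(-c3ccncc3)nnc2s1)\c1ccco1`: 82%
Compound 2 `Fc1cccc(-c2nnc3sc(CCc4ccccc4)nn23)c1`: 50%

In an assay for inhibition of histone-lysine N-methyltransferase, H3 lysine-79 specific (Homo sapiens), read by scintillation counting, with stated times of 15 min and 60 min, tested at 100 uM, in the presence of a further agent that is not named here (a higher number here means a stronger effect of the compound at the concentration tested, a lower number a weaker effect), compound 1 gives 82%, the highest of the two numbers recorded. Compound 2 gives 50%, a number that lies below compound 1 by a gap beyond the usual scatter. Compound 3 `Fc1cccc(-c2nnc3sc(/C=C/c4ccco4)nn23)c1` has not yet been measured. It differs from compound 1 in one place: 3-fluorophenyl in place of pyridin-4-yl on an aromatic carbon. Among the compounds with values here, compound 2 also carries a 3-fluorophenyl group, but it differs from compound 1 and from compound 3 in a second part of the molecule as well, so no step between two measured compounds isolates this single change. With compound 1 at 82% and compound 2 at 50% as the only anchors, the step of a number 12 percentage points lower from compound 1 to compound 3 (beyond the scatter) is expected to be a modest decrease, close to the edge of the scatter. For compound 3 the expected value in this assay is 70%, with a range from 45% to 90%.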

Compound 3, a percentage reported as inhibition, at one concentration (the size of the read-out at that concentration, not a potency): 29%
Beside the measured number, compound 3's estimate is 41 percentage points above it; measured number outside the range, below it.
By their numbers in this assay, from the lowest: compound 3; then compound 2; then compound 1.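

In this assay, the place on the aromatic carbon between two ring nitrogen atoms now has a single change measured on its own: 3-fluorophenyl in place of pyridin-4-yl gives a number 53 percentage points lower from compound 1 to compound 3 (beyond the scatter) with the rest of the molecule unchanged. Within the data shown here, this shows that the read-out depends strongly on the group at this place, which the earlier compounds could not show because they differ in a second part as well. The group that leaves carries one hydrogen-bond acceptor and the group that enters none, but nothing measured here explains the loss.

The compounds shown leave open whether the loss follows from the ring nitrogen leaving or from the fluorine entering, which a plain phenyl group would help to separate. Also open, from the compounds shown here alone, is how pyridin-3-yl or a pyridin-4-yl ring bearing an amine would read at this place.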